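The compounds below may be only part of what the source reports. "The series", "measured", "known", "first", "only" and "open" are said of these compounds alone.

In a functional assay on PC-3 cells (Homo sapiens) for inhibition, read by MTT assay, with a stated time of 48 h, tested at 10 uM (on this read-out higher numbers stand for more inhibition of growth at the one concentration tested and lower numbers for less inhibition of growth), compound 2 `CN1CC[C@H](c2c(O)cc(O)c3c(=O)cc(/C=C/c4cccc(F)c4)oc23)[C@H](O)C1` gives 67% and is the lower of the two measured compounds, with compound 1 `CN1CC[C@H](c2c(O)cc(O)c3c(=O)cc(/C=C/c4c(F)c(F)c(F)c(F)c4F)oc23)[C@H](O)C1` at 82% for comparison. Compound 3 `CN1CC[C@H](c2c(O)cc(O)c3c(=O)cc(/C=C/c4ccccc4Cl)oc23)[C@H](O)C1` differs from compound 2 in one group: 2-chlorophenyl in place of 3-fluorophenyl on a double-bonded chain carbon bound to a double-bonded chain carbon on a double-bonded chain carbon bound to a double-bonded chain carbon. For the measured compounds named here, the only measured step at this place is a number 15 percentage points lower from compound 1 to compound 2 (beyond the scatter) and it is modest, so no change beyond the scatter is expected in this assay here. The expected step is a number 3 percentage points higher from compound 2 to compound 3 (within the scatter) and it has no firm direction. Compound 3 is estimated at 70% with an expected range of 55% to 84% in this measurement.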

Compound 3, percent growth inhibition at one concentration: 22%
Beside the measured number, compound 3's estimate is 48 percentage points above it; measured number below the stated range.
By their numbers in this assay, from the lowest: compound 3; then compound 2; then compound 1.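

For the compounds shown here, changing the group at this place to 2-chlorophenyl gives a number 45 percentage points lower from compound 2 to compound 3 (beyond the scatter) and a number 60 percentage points lower from compound 1 to compound 3 (beyond the scatter) in this assay so this position is far less tolerant than the first pair of compounds suggested. 3-fluorophenyl and 2-chlorophenyl have the same heavy-atom count and neither has hydrogen-bond donors or acceptors, so these counts do not separate compound 2 from compound 3. Nothing available explains the drop. On these data alone, whether the kind of halogen or its place on the ring matters remains open. So does how a phenyl carrying an amine or a carboxylic acid would fare here.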